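A few compounds are considered here, and "the series" means these few. Any claim that something is new, unique, unknown or untested is made for them only; others in the source may bear on it.

In a functional assay on Huh-7 cells (Homo sapiens) for inhibition, read by MTT assay, with a stated time of 48 h (a higher number here means a weaker inhibitor, a lower number a stronger inhibitor), compound 1 `COc1ccc2c(=O)c(/C=C/C(=O)Nc3ccccc3)coc2c1` gives 9050 nM. Compound 2 `O=C(/C=C/c1coc2cc(O)ccc2c1=O)NCc1ccccc1` gives 4690 nM in this assay, a number that lies within the usual scatter of the number for compound 1, so the two cannot be told apart. Compound 3 `Cc1ccc(CNC(=O)/C=C/c2coc3cc(O)ccc3c2=O)cc1` gives > 100000 nM in this assay; this is a limit of the assay, not a number (the limit of > 100000 nM in this assay, at which 1 of the 3 values shown sits). Between those two, an at least 21-fold higher number from compound 2 to compound 3 (1.32 log units; beyond the scatter). Compound 4 `COc1ccc2c(=O)c(/C=C/C(=O)Nc3cccc(C)c3)coc2c1` differs from compound 1 by methyl in place of hydrogen on an aromatic carbon. For the measured compounds named here, only one measured step bears on this change, and it was large and weakening, so a weakening step is expected here too. Compound 4 is therefore expected to give 35000 nM, between 9000 nM and 100000 nM, a step of a 3.9-fold higher number from compound 1 to compound 4 (0.59 log units; beyond the scatter).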

Compound 4, half-maximal inhibitory concentration: 15500 nM
Compound 4: the middle estimate sits 2.3-fold (0.35 log units) above what was measured, within the range that was stated.
By their numbers in this assay, from the lowest: compounds 2, 1 and 4 (each within the scatter of the next, the first and the last beyond it). At a limit, above all of these: compound 3.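

The change from phenyl to 3-methylphenyl on the core of compound 1 gives a 1.7-fold higher number from compound 1 to compound 4 (0.23 log units; within the scatter), so in this assay the methyl at this place cannot be told from hydrogen. The large step seen earlier therefore does not hold for every pair carrying this change: the same change on two cores in this assay, an at least 21-fold higher number (1.32 log units; beyond the scatter) from compound 2 to compound 3 and a 1.7-fold higher number (0.23 log units; within the scatter) from compound 1 to compound 4, at least 12-fold (1.09 log units) apart, beyond the scatter of two such steps. Compound 3 stands at a limit of the assay, not at a number: the limit of > 100000 nM in this assay, at which 1 of the 4 values shown sits.

Still open, on these data alone, is whether a chlorine atom or an amine at this place would separate from hydrogen. Also open, as far as these compounds go, is whether a methyl elsewhere on this ring would behave the same way.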